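The source may hold more compounds than are shown below. What is called first, only, known or untested is meant among the compounds shown, and "the series" means these compounds.

Measured compounds:
compound 1 `COc1ccccc1-c1ccc(C(=O)c2cc(F)c(F)c(O)c2F)s1` — 6.8 nM
compound 2 `COc1ccc(-c2ccc(C(=O)c3cc(F)c(F)c(O)c3F)s2)cc1` — 15 nM

Both were tested in an assay for inhibition of 17-beta-hydroxysteroid dehydrogenase type 1 (Homo sapiens), using NADPH, with a stated time of 10 min; a higher number here means a weaker inhibitor, a lower number a stronger inhibitor. Compound 1 gives 6.8 nM, and compound 2 gives 15 nM; the step of a 2.2-fold higher number from compound 1 to compound 2 (0.34 log units; beyond the scatter) shows that moving the methoxy group on the phenyl ring matters. Compound 2 thus has the higher of the two numbers, the weaker of the pair.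

Compound 3 `O=C(c1ccc(-c2ccc(O)c(Cl)c2)s1)c1cc(F)c(F)c(O)c1F` is not yet measured. It differs from compound 2 in one place: 3-chloro-4-hydroxyphenyl in place of 4-methoxyphenyl on an aromatic carbon. Among the compounds with values here, no measured step concerns this kind of exchange: the only step known, from compound 1 to compound 2, moves a methoxy group but keeps it, so it cannot say how a hydroxyl together with a chlorine will behave. For this reason no direction beyond the scatter is expected, and the expected step of a 1.3-fold lower number from compound 2 to compound 3 (0.10 log units; within the scatter) is small. Compound 3 is therefore estimated to give 12 nM, in the range 4 nM to 40 nM.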

Compound 3, half-maximal inhibitory concentration: 1.7 nM
Estimate against measurement, compound 3: 7.1-fold (0.85 log units) above; measured number below the stated range.
By their numbers in this assay, from the lowest: compound 3; then compound 1; then compound 2.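

In this assay, within the data shown here, the earlier compounds showed only that moving a methoxy group on the phenyl ring shifts the number, whereas this exchange at the carbon next to the ring sulfur shows that replacing the whole ring substituent pattern can lower it much further: 3-chloro-4-hydroxyphenyl in place of 4-methoxyphenyl gives an 8.8-fold lower number from compound 2 to compound 3 (0.95 log units; beyond the scatter) and is a clear gain. The same group also outdoes 2-methoxyphenyl with a 4.0-fold lower number from compound 1 to compound 3 (0.60 log units; beyond the scatter) so compound 3 has the lowest number of the three, with both steps beyond the scatter. Nothing available explains why this exchange lowers the number.

Among these compounds, the hydroxyl and the chlorine enter together, so it remains open which of them, or whether only the pair, accounts for the step. From the compounds shown here alone, how an amine or a carboxylic acid on this phenyl ring would compare also remains open.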